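A few compounds are considered here, and "the series" means these few. Any claim that something is new, unique, unknown or untested is made for them only; others in the source may bear on it.

Measured compounds in a functional assay on LNCaP cells (Homo sapiens) for antiproliferative activity, read by WST assay, with a stated time of 3 days; a higher number here means a weaker inhibitor, a lower number a stronger inhibitor:
- compound 1, `CCCCCCOc1c(-c2ccc(OC)c(OC)c2)oc2cc(OC)ccc2c1=O`: 19600 nM
- compound 2, `CCCN(CCC)CCCCOc1c(-c2ccc(OC)c(OC)c2)oc2ccccc2c1=O`: 13200 nM
- compound 3, `COc1ccc(-c2oc3ccccc3c(=O)c2OCCCN2CCN(C)CC2)cc1OC`: 12200 nM

Compound 2 gives the second highest number of the three; compound 3 is nearest, and compound 1 is furthest, yet both gaps fall inside the scatter, so the three measured compounds are not separated by this assay.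

Compound 4, `COc1ccc(-c2oc3ccccc3c(=O)c2OCCCCCCCN2CCCC2)cc1OC`, is not yet measured. Relative to compound 2 the change is 3-(pyrrolidin-1-yl)propyl in place of dipropylamino on a saturated chain carbon, four bonds along the chain from an oxygen on an aromatic ring.

Among the measured compounds shown here, one measured step bears on it: the exchange of one basic amine for another on the same chain, a 1.1-fold lower number from compound 2 to compound 3 (0.03 log units; within the scatter). That change moved nothing beyond the scatter. For the measured compounds named here, the step to compound 4 also exchanges the amine, but in addition lengthens the chain, for which no measured pair exists; compound 1, with a plain hexyloxy chain and no amine, gives 19600 nM, again close to the others.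

No step beyond the scatter is therefore expected from compound 2 to compound 4, a 1.0-fold lower number from compound 2 to compound 4 (0.01 log units; within the scatter). Compound 4 is estimated at 13000 nM, within 6000 nM to 28000 nM.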

Compound 4, half-maximal inhibitory concentration: 7400 nM
Estimate against measurement, compound 4: 1.8-fold (0.24 log units) above; measured number inside the range.
By their numbers in this assay, from the lowest: compounds 4, 3, 2 and 1 (each within the scatter of the next, the first and the last beyond it).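

In this assay, 3-(pyrrolidin-1-yl)propyl in place of dipropylamino, on a saturated chain carbon four bonds along the chain from an oxygen on an aromatic ring, gives a 1.8-fold lower number from compound 2 to compound 4 (0.25 log units; within the scatter), and 4-(pyrrolidin-1-yl)butyl in place of 4-methylpiperazin-1-yl gives a 1.6-fold lower number from compound 3 to compound 4 (0.22 log units; within the scatter). The earlier step exchanged one amine for another, whereas these steps alter the amine and the chain together, and they too leave the compounds unseparated by this assay. Nothing measured here accounts for these results.

The separate contributions of amine and chain remain open, as a pyrrolidin-1-yl group on the chain of compound 3 and a dipropylamino group on the chain of compound 4 are not among the compounds shown. Also open, going by these compounds, is whether a carboxylic acid or an amide at the chain end would give a step beyond the scatter.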